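This account rests on a few compounds, and the source may have more. Where it says the series, first, only, none or still open, it means among the compounds named here.

Measured so far in an assay for inhibition of Retinaldehyde dehydrogenase 3 (Homo sapiens), with a stated time of 5 min; a lower number here means a stronger inhibitor, a higher number a weaker inhibitor:
compound 1 `Fc1ccc(-c2ccc3nc(-c4ccccc4)cn3c2)cc1` — 22800 nM
compound 2 `Clc1ccc(-c2ccc3nc(-c4ccccc4)cn3c2)cc1` — 45800 nM

Compound 1 holds the lowest of the two numbers; its nearest neighbour is compound 2, and a 2.0-fold higher number from compound 1 to compound 2 (0.30 log units; within the scatter) keeps the pair within the scatter.

Compound 3 `CSc1ccc(-c2ccc3nc(-c4ccccc4)cn3c2)cc1` carries methylsulfanyl in place of fluoro on an aromatic carbon. Among the compounds with values here, the one step that bears on a change at this carbon is a 2.0-fold higher number from compound 1 to compound 2 (0.30 log units; within the scatter), and it did not leave the scatter. On that basis no step beyond the scatter is expected for compound 3 in this assay, with a 1.1-fold higher number from compound 1 to compound 3 (0.04 log units; within the scatter) as the estimated move. The estimate for compound 3 is 25000 nM, within 8000 nM to 80000 nM.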

Compound 3, half-maximal inhibitory concentration: 27100 nM
Compound 3: the middle estimate sits 1.1-fold (0.04 log units) below what was measured; measured number inside the range.
By their numbers in this assay, from the lowest: compounds 1, 3 and 2 (each within the scatter of the next).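

In this assay methylsulfanyl on this aromatic carbon, para to a large group, stays within the scatter of both halogens (a 1.2-fold higher number from compound 1 to compound 3 (0.08 log units; within the scatter); a 1.7-fold lower number from compound 2 to compound 3 (0.23 log units; within the scatter)). The earlier step only exchanged one halogen for another, whereas this change brings in a second heavy atom and a hydrogen-bond acceptor without a step beyond the scatter. No evidence is available on what lies behind these close values.

Going by these compounds, whether an amine, a carboxylic acid or a longer chain on this carbon would leave the scatter remains open. Changes elsewhere on the shared core also remain open.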